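An Aryl Group Returns to the Amide Nitrogen

The source may hold more compounds than are shown below. What is called first, only, known or untested is meant among the compounds shown, and "the series" means these compounds.

In a functional assay on MCF7 cells (Homo sapiens) for antiproliferative activity, read by MTT assay, with a stated time of 72 h (a higher number here means a weaker inhibitor, a lower number a stronger inhibitor), compound 1 `COc1ncc(-c2ccc3c(c2)NC(=O)CO3)cc1NS(=O)(=O)c1ccc(F)cc1` gives 32300 nM, compound 2 `COc1ncc(-c2ccc3c(c2)N(c2ccccc2)C(=O)CO3)cc1NS(=O)(=O)c1ccc(F)cc1` gives 8870 nM and compound 3 `COc1ncc(-c2ccc3c(c2)N(C2CC2)C(=O)CO3)cc1NS(=O)(=O)c1ccc(F)cc1` gives 35200 nM. Compound 3 therefore stands level with compound 1, as cyclopropyl in place of the hydrogen gives a 1.1-fold higher number from compound 1 to compound 3 (0.04 log units; within the scatter). Phenyl in place of the hydrogen gives a 3.6-fold lower number from compound 1 to compound 2 (0.56 log units; beyond the scatter), and cyclopropyl in place of phenyl gives a 4.0-fold higher number from compound 2 to compound 3 (0.60 log units; beyond the scatter). Compound 4 `COc1ccc(N2C(=O)COc3ccc(-c4cnc(OC)c(NS(=O)(=O)c5ccc(F)cc5)c4)cc32)cc1` carries 4-methoxyphenyl in place of cyclopropyl on an amide-type nitrogen in a ring. Among the measured compounds shown here, no measured compound carries 4-methoxyphenyl, so the phenyl steps are the nearest guide, and a modest move to a lower number is expected. The expected step is a 3.5-fold lower number from compound 3 to compound 4 (0.55 log units; beyond the scatter). Compound 4 is estimated at 10000 nM, with an expected range of 4000 nM to 25000 nM.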

Compound 4, half-maximal inhibitory concentration: 8260 nM
The estimate for compound 4 lay 1.2-fold (0.08 log units) above the measured number, and the stated range covers the measured number.
By their numbers in this assay, from the lowest: compounds 4 and 2 (each within the scatter of the next); then compounds 1 and 3 (each within the scatter of the next).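

The gain seen with phenyl at this amide-type nitrogen persists with 4-methoxyphenyl, both against cyclopropyl (a 4.3-fold lower number from compound 3 to compound 4 (0.63 log units; beyond the scatter)) and against hydrogen (a 3.9-fold lower number from compound 1 to compound 4 (0.59 log units; beyond the scatter)). Methoxy in place of hydrogen on an aromatic carbon of the phenyl group leaves this assay unchanged (a 1.1-fold lower number from compound 2 to compound 4 (0.03 log units; within the scatter)), so this change adds nothing measurable here. No evidence accompanies these compounds that would explain the result. On these data alone, whether an amine or a carboxylic acid in place of the methoxy group would also leave the number unchanged remains open. So does the outcome of a benzyl group or a longer chain on this nitrogen.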